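Bromo for chloro on the aromatic ring of compound 1

This account rests on a few compounds, and the source may have more. Where it says the series, first, only, none or still open, it means among the compounds named here.

Measured so far:
compound 1 `CCNS(=O)(=O)Cc1noc2ccc(Cl)cc12` — 21 mg/kg
compound 2 `CN(C)S(=O)(=O)Cc1noc2ccc(Cl)cc12` — 57 mg/kg

In a functional assay on the whole organism (strain STD-dd) with Mus musculus as the target, in the maximal electroshock model, with a stated time of 2 h (on this read-out lower numbers stand for an effect already at smaller amounts and higher numbers for an effect only at larger amounts of compound), compound 1 gives 21 mg/kg, the lowest of the two numbers. Compound 2 gives 57 mg/kg. Within the data shown here, the one measured step, a 2.7-fold higher number from compound 1 to compound 2 (0.43 log units; beyond the scatter), concerns only the group on the sulfonyl sulfur. Compound 3 `CCNS(=O)(=O)Cc1noc2ccc(Br)cc12` differs from compound 1 by bromo in place of chloro on an aromatic carbon. Among the measured compounds shown here, no measured step touches that place, so nothing in these data speaks for a change beyond the scatter. Compound 3 is therefore expected to give about 21 mg/kg, between 10 mg/kg and 45 mg/kg. This estimate means an expected step of no change at the digits printed from compound 1 to compound 3 (within the scatter), within the scatter.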

Compound 3, dose for half-maximal effect: 18 mg/kg
The estimate for compound 3 lay 1.2-fold (0.07 log units) above the measured number; measured number inside the range.
By their numbers in this assay, from the lowest: compounds 3 and 1 (each within the scatter of the next); then compound 2.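

On the aromatic carbon, the first step measured at this place gives a 1.2-fold lower number from compound 1 to compound 3 (0.07 log units; within the scatter) and so shows that bromo and chloro cannot be told apart here, whereas the earlier step concerned only the group on the sulfonyl sulfur. For this pair of halogens, the position shows no difference beyond the scatter. No measured evidence bears on this result.

The compounds shown leave open whether a group other than these halogens, such as methoxy or a nitrile, would keep the number within the scatter of compound 1. They also leave open whether bromo would give the same small step alongside the dimethylamino group of compound 2.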